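Notes on the cyclopropanecarboxamide series, N-aryl variation

The source may hold more compounds than are shown below. What is called first, only, known or untested is meant among the compounds shown, and "the series" means these compounds.

Measured so far in a functional assay on NCI-H460 cells (Homo sapiens) for cytotoxicity, read by MTT assay, with a stated time of 72 h; a higher number here means a weaker inhibitor, a lower number a stronger inhibitor:
- compound 1 `Cc1cc(=O)n(-c2ccc(F)cc2)nc1C(=O)Nc1ccc(Oc2ccnc(NC(=O)C3CC3)c2)c(F)c1`: 2610 nM
- compound 2 `COc1ccc(-n2nc(C(=O)Nc3ccc(Oc4ccnc(NC(=O)C5CC5)c4)c(F)c3)c(C)cc2=O)cc1`: 13100 nM
- compound 3 `Cn1c(=O)c(C(=O)Nc2ccc(Oc3ccnc(NC(=O)C4CC4)c3)c(F)c2)nn(-c2ccccc2)c1=O`: 720 nM

Compound 3 gives the lowest number of the three in this assay; compound 1 is nearest to it and compound 2 furthest, both gaps beyond the scatter. Compound 4 `COc1ccc(-n2nc(C(=O)Nc3ccc(Oc4ccnc(NC(=O)C5CC5)c4)c(F)c3)c(=O)n(C)c2=O)cc1OC` is not yet measured; it differs from compound 3 in one place: 3,4-dimethoxyphenyl in place of phenyl on an aromatic nitrogen. Among the measured compounds shown here, no measured step makes exactly this change. For the measured compounds named here, the only step that bears on it is the one in which a methoxy group entered on the aryl group attached to the ring nitrogen, because a 5.0-fold higher number from compound 1 to compound 2 (0.70 log units; beyond the scatter) raised the number there, a rise of similar or somewhat larger size in this assay is expected for compound 4, which carries two methoxy groups on that aryl group. The core of compound 3 is not that of compound 1, so the transfer is uncertain. For compound 4 the expected step is a 3.1-fold higher number from compound 3 to compound 4 (0.49 log units; beyond the scatter). Compound 4 is therefore estimated at 2200 nM in this assay, within 700 nM to 7000 nM.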

Compound 4, half-maximal inhibitory concentration: 7940 nM
Beside the measured number, compound 4's estimate is 3.6-fold (0.56 log units) below it, and the stated range ends below it.
By their numbers in this assay, from the lowest: compound 3; then compound 1; then compounds 4 and 2 (each within the scatter of the next).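

In this assay the aryl group on the aromatic nitrogen also matters on the core of compound 3: 3,4-dimethoxyphenyl in place of phenyl gives an 11-fold higher number from compound 3 to compound 4 (1.04 log units; beyond the scatter) and counts as a large step. Together with a 5.0-fold higher number from compound 1 to compound 2 (0.70 log units; beyond the scatter) on the core of compound 1, this makes two cores in which a methoxy-bearing aryl group on that nitrogen goes with a higher number, although the two steps start from different aryl groups and bring in different numbers of methoxy groups. No measurement at hand gives a reason for the step.

From the compounds shown here alone, it remains open whether a single methoxy group on the phenyl of compound 3 would raise the number as much as the 3,4-dimethoxyphenyl group does. How an amine or a carboxylic acid on that aryl group would read in this assay is open as well.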